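Cytotoxicity notes on a pyrazolo-fused cyclopentylamino series

The source may hold more compounds than are shown below. What is called first, only, known or untested is meant among the compounds shown, and "the series" means these compounds.

Measured compounds:
compound 1 `Fc1ccc(-c2nn3c(NC4CCCC4)cccc3c2-c2ccc3[nH]ccc3c2)cc1`, 20000 nM
compound 2 `Fc1ccc(-c2nn3c(NC4CCCC4)cccc3c2-c2ccnnc2)cc1`, "not determined" (no result reported)
compound 3 `Cc1nc(-c2c(-c3ccc(F)cc3)nn3c(NC4CCCC4)cccc23)co1`, "not determined" (no result reported)

In an ADME assay on Vero cells (Chlorocebus sabaeus) for cytotoxicity (a higher number here means that more compound is tolerated, a lower number that less compound is tolerated), compound 1 gives 20000 nM. For the measured compounds named here, this is the only number in the set; for compound 2 the entry reads "not determined" (no result reported), and for compound 3 it reads "not determined" (no result reported). Going by the values given here, compound 1 therefore stands alone, with nothing to rank it against, and no step between measured compounds can be drawn.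

Compound 4 `NNc1cc(-c2c(-c3ccc(F)cc3)nn3c(NC4CCCC4)cccc23)ccn1` is the next entry for this assay. Relative to compound 1 the change is 2-(aminoamino)pyridin-4-yl in place of 1H-indol-5-yl on an aromatic carbon. The shared core and the 4-fluorophenyl group stay as they are.

Among the compounds with values here, with no measured step available, the expectation rests on compound 1 alone. The step from compound 1 to compound 4 is estimated as no change at the digits printed from compound 1 to compound 4 (within the scatter), that is, no shift beyond the usual scatter of this assay in either direction. For compound 4 the expected half-maximal cytotoxic concentration is 20000 nM, with a range from 8000 nM to 50000 nM. A result reported only as a limit is also possible for compound 4.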

Compound 4, half-maximal cytotoxic concentration: 40000 nM
Beside the measured number, compound 4's estimate is 2.0-fold (0.30 log units) below it; measured number inside the range.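

In this assay, 2-(aminoamino)pyridin-4-yl in place of 1H-indol-5-yl gives a 2.0-fold higher number from compound 1 to compound 4 (0.30 log units; within the scatter). For the compounds shown here, this is the first reading of a change at this aromatic carbon, which sits next to the ring atom that bears the 4-fluorophenyl group: a group with one six-membered aromatic ring, 2 hydrogen-bond donors and 3 hydrogen-bond acceptors replaces one with a five-membered and a six-membered aromatic ring, 1 hydrogen-bond donor and 0 hydrogen-bond acceptors, and the two numbers cannot be told apart beyond the scatter. No supporting data accompany this single step, so nothing can be said about what underlies it.

Steps involving compound 2 or compound 3 cannot be read, as neither entry holds a number. As far as these compounds go, it remains open whether an amine or a carboxylic acid in place of the aminoamino part of the entering group would also stay within the scatter, and whether the same holds for a change elsewhere, such as a longer chain in place of the cyclopentyl group.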